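The compounds below may be only part of what the source reports. "The series", "measured", "known", "first", "only" and "open" are said of these compounds alone.

Compound 2 `N=C(NO)c1cccc2c1nc(-c1c(F)cccc1F)n2Cc1c(F)cccc1F` carries a group of four heavy atoms on the shared core. In a toxicity assay on CCRF-CEM cells (Homo sapiens) for cytotoxicity (on this read-out lower numbers stand for higher toxicity in this test and higher numbers for lower toxicity in this test), compound 2 gives 23.1 uM, the highest of the two numbers measured. Compound 3 `Fc1cccc(F)c1Cn1c(-c2c(F)cccc2F)nc2c(CCl)cccc21` bears chloromethyl at the same place, and in this assay compound 3 gives 13.4 uM, so that a 1.7-fold lower number from compound 2 to compound 3 (0.24 log units; within the scatter). Compound 1 `Oc1cccc2c1nc(-c1c(F)cccc1F)n2Cc1c(F)cccc1F` carries hydroxy there; in this assay compound 1 gives > 100 uM, which is a limit of the assay rather than a number. From this limit of > 100 uM in this assay, at which 1 of the 3 values shown sits, it follows that an at least 4.3-fold lower number from compound 1 to compound 2 (0.63 log units; beyond the scatter) and an at least 7.4-fold lower number from compound 1 to compound 3 (0.87 log units; beyond the scatter).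

Compound 4 `CC(=O)N(C)Cc1cccc2c1nc(-c1c(F)cccc1F)n2Cc1c(F)cccc1F` is not yet measured. It differs from compound 2 in one place: a group of 6 heavy atoms (4 carbon, 1 nitrogen, 1 oxygen; no ring) in place of a group of 4 heavy atoms (1 carbon, 2 nitrogen, 1 oxygen; no ring), on an aromatic carbon. Within the data shown here, the one measured exchange at this position between two numbered values, from compound 2 to compound 3, stayed within the scatter, while hydroxy in compound 1 stood apart. Compound 4 keeps a substituent of comparable kind at that carbon, so a step within the scatter is expected; the estimate is a 1.1-fold higher number from compound 2 to compound 4 (0.03 log units; within the scatter), giving compound 4 an expected value of 25 uM, between 8 uM and 80 uM.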

Compound 4, half-maximal toxic concentration: 20.6 uM
Compound 4: the middle estimate sits 1.2-fold (0.08 log units) above what was measured; the measured number falls inside the stated range.
By their numbers in this assay, from the lowest: compounds 3, 4 and 2 (each within the scatter of the next). At a limit, above all of these: compound 1.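

In this assay, the (acetyl(methyl)amino)methyl group takes the count of hydrogen-bond donors at this aromatic carbon from 3 to 0, yet the step stays within the scatter: a 1.1-fold lower number from compound 2 to compound 4 (0.05 log units; within the scatter). The comparison with chloromethyl also stays within the scatter: a 1.5-fold higher number from compound 3 to compound 4 (0.19 log units; within the scatter). Hydroxy therefore remains the only group shown that stands apart, with an at least 4.8-fold lower number from compound 1 to compound 4 (0.68 log units; beyond the scatter), and the value of compound 1 is a limit rather than a number: the limit of > 100 uM in this assay, at which 1 of the 4 values shown sits.

From the compounds shown here alone, it remains open whether a basic amine, a carboxylic acid or a longer chain at this carbon would stay level with compound 2, compound 3 and compound 4. Going by these compounds, the true value of compound 1 also remains unknown, so the full size of its steps to the others is open.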